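Tertiary amine variation in an aryl sulfamate series

The source may report more compounds than this note shows. Statements on the series, on what has been measured and on what is new or still open speak of the compounds shown alone.

Measured in an assay on HEK293 cells for inhibition of Steryl-sulfatase (Homo sapiens), tested at 1 uM; a lower number here means a weaker effect, a higher number a stronger effect of the compound at the concentration tested:
compound 1 `CN(C)CCN(CCN(C)C)c1ccc(C(=O)N2CCc3ccc(OS(N)(=O)=O)cc3C2)cc1` gives 15.9%
compound 2 `CCN(Cc1ccncc1)c1ccc(C(=O)N2CCc3ccc(OS(N)(=O)=O)cc3C2)cc1` gives 86.6%
compound 3 `CCN(Cc1ccccc1)c1ccc(C(=O)N2CCc3ccc(OS(N)(=O)=O)cc3C2)cc1` gives 83.6%

Compound 3 is second highest of the three numbers; its nearest neighbour is compound 2, a number 3 percentage points lower from compound 2 to compound 3 (within the scatter), and its furthest is compound 1, a number 67.7 percentage points higher from compound 1 to compound 3 (beyond the scatter). Compound 4 `CCCN(CCC)c1ccc(C(=O)N2CCc3ccc(OS(N)(=O)=O)cc3C2)cc1` is the next analogue: dipropylamino in place of benzyl(ethyl)amino on an aromatic carbon. Going by the values given here, the steps that bear on this are a number 67.7 percentage points higher from compound 1 to compound 3 (beyond the scatter) and a number 70.7 percentage points higher from compound 1 to compound 2 (beyond the scatter), both large, while a number 3 percentage points lower from compound 2 to compound 3 (within the scatter) shows the two ring-bearing amines behaving alike. Among the compounds with values here, no measured step removes the ring from the amine, so the size of a number 9.6 percentage points lower from compound 3 to compound 4 (within the scatter) is expected to be small to moderate downward, possibly none beyond the scatter. Compound 4 is estimated at 74%, range 50% to 92%.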

Compound 4, a percentage reported as inhibition, at one concentration (the size of the read-out at that concentration, not a potency): 84.7%
Estimate against measurement, compound 4: 10.7 percentage points below, within the range that was stated.
By their numbers in this assay, from the lowest: compound 1; then compounds 3, 4 and 2 (each within the scatter of the next).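

Removing the aromatic ring from the amine leaves the read-out in this assay unchanged within the scatter, with a number 1.1 percentage points higher from compound 3 to compound 4 (within the scatter) and a number 1.9 percentage points lower from compound 2 to compound 4 (within the scatter), so a ring on this nitrogen is not required. The step of a number 68.8 percentage points higher from compound 1 to compound 4 (beyond the scatter) joins two amines that both lack a ring, so the low number of compound 1 cannot be tied to the missing ring. No supporting data explain either result. Still open, going by these compounds, is whether a single 2-(dimethylamino)ethyl chain paired with a propyl chain lowers the number. Also open, on these data alone, is how a morpholine or a longer chain such as dihexylamino behaves here.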